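The compounds below may be only part of what the source reports. "The series", "measured", "known", "first", "only" and "open" are said of these compounds alone.

Measured in an ADME assay on Vero cells (Chlorocebus sabaeus) for cytotoxicity, read by MTT assay, with a stated time of 72 h; on this read-out lower numbers stand for higher toxicity in this test and higher numbers for lower toxicity in this test:
compound 1 `CCOC(=O)CCN1CCN(c2c(F)cc3c(=O)c(C(=O)O)cn(C4CC4)c3c2OC)CC1C`: "not determined" (no result reported)
compound 2 `COc1c(N2CCN(CCC(C)=O)C(C)C2)c(F)cc2c(=O)c(C(=O)O)cn(C3CC3)c12`: 9.84 ug/mL
compound 3 `CCO/N=C(\C)CCN1CCN(c2c(F)cc3c(=O)c(C(=O)O)cn(C4CC4)c3c2OC)CC1C`: 88.4 ug/mL

Going by the values given here, compound 3 holds the highest number in this assay, but compound 2 is its only numerical comparison, and compound 1 gives no number. The next compound to be read is compound 4 `COc1c(N2CCN(O)C(C)C2)c(F)cc2c(=O)c(C(=O)O)cn(C3CC3)c12`, which differs from compound 3 as follows: one oxygen atom in place of a group of 8 heavy atoms (6 carbon, 1 nitrogen, 1 oxygen; no ring), on an amine nitrogen in a ring. In compound 4, hydroxy stands on an amine nitrogen in a ring, the place that holds the larger group in compound 3.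

Among the compounds with values here, only one measured step bears on this change: a 9.0-fold higher number from compound 2 to compound 3 (0.95 log units; beyond the scatter). It is modest but beyond the scatter, and it involves a change within the chain, not the loss of the whole chain. Within the data shown here, no measured compound carries hydroxy, so this step is only a loose guide. Among the measured compounds shown here, compound 3, at 88.4 ug/mL, is the higher of only two numbers, so a lower number is expected for the next compound, with a drop somewhat smaller than the measured step. The estimated change is a 4.4-fold lower number from compound 3 to compound 4 (0.65 log units; beyond the scatter). For compound 4 the expected value is 20 ug/mL, with an estimated range of 5 ug/mL to 90 ug/mL.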

Compound 4, half-maximal cytotoxic concentration: 19.7 ug/mL
Compound 4: the middle estimate sits 1.0-fold (0.01 log units) above what was measured; low and high end bracket the measured number.
By their numbers in this assay, from the lowest: compounds 2 and 4 (each within the scatter of the next); then compound 3.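

In this assay the amine nitrogen in the ring now has a reading with the whole chain gone: one oxygen atom in place of the group of 8 heavy atoms gives a 4.5-fold lower number from compound 3 to compound 4 (0.65 log units; beyond the scatter) and shows that the higher number of compound 3 is not kept when that chain is lost. Hydroxy in place of 2-acetylethyl gives a 2.0-fold higher number from compound 2 to compound 4 (0.30 log units; within the scatter) and leaves compound 2 and compound 4 unseparated, so a single oxygen atom and a full chain can read alike at this position, and among the three numbers only the chain of compound 3 stands apart. No measurement shown here gives a reason for either step.

Still open, from the compounds shown here alone, is whether the number of compound 3 depends on the whole chain or only on its far end, a question that a chain of the same length ending in a carboxylic acid or an amine on the same ring nitrogen would address. Compound 1, with its ethyl ester chain, gives "not determined" (no result reported) and adds no comparison at this position.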